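Halogen swap on the aryl ketone of compound 1

This account rests on a few compounds, and the source may have more. Where it says the series, first, only, none or still open, it means among the compounds named here.

Compound 1, `O=C(/C=C/c1cccc(OCc2ccccc2)c1)c1ccccc1Br`, gives 1200 nM in a functional assay on 2008 cells (Homo sapiens) for cytotoxicity, read by MTT assay, with a stated time of 68 h (on this read-out lower numbers stand for stronger inhibition and higher numbers for weaker inhibition), the lowest of the two numbers in hand. Compound 2, `O=C(/C=C/c1cccc(OCc2ccccc2)c1)c1cccc(Br)c1`, gives 5700 nM in this assay. For the measured compounds named here, the only measured step, a 4.8-fold higher number from compound 1 to compound 2 (0.68 log units; beyond the scatter), shows that moving the single bromine on the ring attached to the carbonyl carbon costs potency beyond the scatter.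

Compound 3, `O=C(/C=C/c1cccc(OCc2ccccc2)c1)c1ccc(Cl)cc1Cl`, is yet to be measured. Its change from compound 1 is 2,4-dichlorophenyl in place of 2-bromophenyl on a carbonyl carbon. Going by the values given here, no measured pair tests a chlorine for a bromine or a second halogen on that ring, so the step from compound 1 to compound 2 bears on it only loosely: the 2-substituted pattern that is retained in compound 3 is the one that gave the lower number in compound 1. On this basis, a step within or near the scatter is expected, in no firm direction, as a 1.3-fold higher number from compound 1 to compound 3 (0.10 log units; within the scatter). Compound 3 is thus expected at 1500 nM, with a range of 500 nM to 4500 nM.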

Compound 3, half-maximal inhibitory concentration: 5200 nM
For compound 3 the middle estimate is 3.5-fold (0.54 log units) below the measured one; the whole stated range lies below it.
By their numbers in this assay, from the lowest: compound 1; then compounds 3 and 2 (each within the scatter of the next).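

In this assay, 2,4-dichlorophenyl on the carbonyl carbon does not keep the standing of 2-bromophenyl: the data show a 4.3-fold higher number from compound 1 to compound 3 (0.64 log units; beyond the scatter) and place compound 1 lowest of the three, with both of its steps beyond the scatter. The further comparison gives a 1.1-fold lower number from compound 2 to compound 3 (0.04 log units; within the scatter) and so does not separate 2,4-dichlorophenyl from 3-bromophenyl; among these three groups, the lower number belongs to 2-bromophenyl alone, not to every halogenated phenyl at this place.

Still open, on these data alone, is whether a single chlorine on this ring would match the bromine of compound 1, and whether an amine or a carboxylic acid on the ring would hold its number. No evidence at hand bears on why these groups differ.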